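Taking the Chlorines off a Low-Nanomolar Compound

A few compounds are considered here, and "the series" means these few. Any claim that something is new, unique, unknown or untested is made for them only; others in the source may bear on it.

In a functional assay on NCI-H1581 cells (Homo sapiens) for antiproliferative activity, read by CCK-8 assay, with a stated time of 72 h (on this read-out lower numbers stand for stronger inhibition and higher numbers for weaker inhibition), compound 1 `COc1cc(OC)c(Cl)c(-c2ccc3c(NC(=O)c4ccc(N5CCN(C)CC5)cc4)n[nH]c3n2)c1Cl` gives 1.7 nM, the lower of the two numbers available. Going by the values given here, its only measured neighbour, compound 2 `COc1cc(OC)c(Cl)c(-c2ccc3c(NC(=O)c4ccc(N(C)CCN(C)C)cc4)n[nH]c3n2)c1Cl`, gives 11 nM. The step between them, a 6.5-fold higher number from compound 1 to compound 2 (0.81 log units; beyond the scatter), comes from placing (2-(dimethylamino)ethyl)(methyl)amino where 4-methylpiperazin-1-yl stood.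

Compound 3 `COc1cc(OC)cc(-c2ccc3c(NC(=O)c4ccc(N5CCN(C)CC5)cc4)n[nH]c3n2)c1` keeps the 4-methylpiperazin-1-yl group and differs elsewhere: 3,5-dimethoxyphenyl in place of 2,6-dichloro-3,5-dimethoxyphenyl on an aromatic carbon. Here 3,5-dimethoxyphenyl replaces 2,6-dichloro-3,5-dimethoxyphenyl. Among the compounds with values here, no measured step touches this place, and no measured compound lacks the chlorines. Within the data shown here, the one step at hand therefore bears only indirectly, showing that a single change can move the number beyond the scatter. A step to a higher number in this assay is expected, probably larger than that one, though its size is poorly constrained. The estimated step is a 29-fold higher number from compound 1 to compound 3 (1.47 log units; beyond the scatter). Compound 3 is expected at 50 nM, within an estimated range of 8 nM to 300 nM.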

Compound 3, half-maximal inhibitory concentration: > 1000 nM
Compound 3 ended at the assay's limit; the forecaster's own chance of this, stated with the estimate: 5%; middle value at least 20-fold (1.30 log units) away from the limit.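

In this assay compound 3 gives > 1000 nM, which is a limit of the assay and not a number: the limit of > 1000 nM in this assay, at which 1 of the 3 values shown sits. Taking the two chlorines off the 2,6-dichloro-3,5-dimethoxyphenyl group, with the rest of the molecule unchanged, produces an at least 580-fold higher number from compound 1 to compound 3 (2.76 log units; beyond the scatter), so the low-nanomolar number of compound 1 depends on these chlorines, at a position the earlier step at the 4-methylpiperazin-1-yl group did not touch. The step is bounded on one side only, and the data do not say why the chlorines matter.

On these data alone, whether a single chlorine would suffice, or whether fluorine or a methyl group could stand in for chlorine, remains open. Also open, as far as these compounds go, is whether the same loss would appear with the (2-(dimethylamino)ethyl)(methyl)amino group of compound 2.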